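The compounds below may be only part of what the source reports. "The series", "measured", "known", "first", "only" and "open" are said of these compounds alone.

The series consists of three measured compounds and one that is still to be measured. Compound 1, `COc1cccc(-c2cc(O)c3c(C)ccnc3n2)c1`, and compound 3, `COc1cccc(-c2cc(O)c3cc(C)cnc3n2)c1`, both carry a methoxyphenyl group and a methyl on the shared core, and they behave alike: in a functional assay on NCI-H460 cells (Homo sapiens) (on this read-out lower numbers stand for stronger inhibition of growth and higher numbers for weaker inhibition of growth), compound 1 gives 47.9 nM, and compound 3 gives 43.7 nM, two numbers that sit within the usual scatter of each other. Compound 2, `Cc1cnc2nc(-c3ccc(Cl)cc3)cc(O)c2c1`, carries a chlorophenyl group instead. In this assay compound 2 gives 3890 nM, the highest number of the three, far beyond the scatter from both compound 1 and compound 3; it is the weakest inhibitor of growth in this set.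

Compound 4, `Oc1cc(-c2ccc(Cl)cc2)nc2ncccc12`, has not yet been measured. It differs from compound 2 in one place: hydrogen in place of methyl on an aromatic carbon. Compound 1 and compound 3 differ only in where the methyl sits, and their values in this assay hardly differ, so the methyl on the core does not seem to govern the read-out here. Compound 4 is therefore expected to stay close to compound 2, with a step of a 1.2-fold lower number from compound 2 to compound 4 (0.08 log units; within the scatter) that is not expected to go beyond the scatter in either direction. Compound 4 is estimated at 3200 nM, in a range from 900 nM to 11000 nM.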

Compound 4, concentration for 50% growth inhibition: 38000 nM
Compound 4: the middle estimate sits 12-fold (1.07 log units) below what was measured; the measured number lies above the stated range.
By their numbers in this assay, from the lowest: compounds 3 and 1 (each within the scatter of the next); then compound 2; then compound 4.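

In this assay, the change from methyl to hydrogen on this aromatic carbon, two atoms from the ring nitrogen, has a clear effect: the result is a 9.8-fold higher number from compound 2 to compound 4 (0.99 log units; beyond the scatter) and lies beyond the scatter, so with the chlorophenyl group present, the methyl at this position matters to the read-out. The earlier compounds shown here could not show this: compound 1 gives 47.9 nM and compound 3 gives 43.7 nM in this assay, two values within the scatter of each other, but both compounds carry a methyl, so they offer no comparison of methyl with hydrogen at any position. No measurement shown here gives a reason for the step.

The compounds shown leave open whether the same change would have a step of similar size with a methoxyphenyl group in place of the chlorophenyl group. They also leave open how an ethyl chain, a methoxy group or an amine on this same aromatic carbon would compare with the methyl of compound 2 in this assay and whether any of them would give a lower number.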